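The compounds below may be only part of what the source reports. "The series", "measured", "known", "first", "only" and "open" are said of these compounds alone.

Of the compounds shown here, two built on one shared core have been tested for their power to kill human lung-cancer cells. Compound 1 has the structure `C=CC1=C(C(=O)NCc2ccc(Cl)cc2)C(c2ccc(F)cc2)OC1`. In a functional assay on A549 cells (Homo sapiens) for cytotoxicity, read by MTT assay, with a stated time of 24 h (a higher number here means a weaker inhibitor, a lower number a stronger inhibitor), compound 1 gives > 100000 nM, which is a limit of the assay rather than a number. Compound 2 has the structure `C=CC1=C(C(=O)Nc2ccccc2)C(c2ccc(F)cc2)OC1`. In this assay compound 2 gives > 100000 nM, again a limit of the assay. The step from compound 1 to compound 2, phenyl in place of 4-chlorobenzyl on an amide-type nitrogen, is a step that the two limits leave unreadable from compound 1 to compound 2. Compound 2 therefore stands at the ceiling of what the assay can report, and nothing separates it from compound 1; both values sit at the limit of > 100000 nM in this assay, at which 2 of the 2 values shown sit.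

Compound 3 has the structure `C=CC1=C(C(=O)NCCCCC)C(c2ccc(F)cc2)OC1`. It differs from compound 2 in one place: pentyl in place of phenyl on an amide-type nitrogen. Among the measured compounds shown here, the only measured step that bears on this change is the one from compound 1 to compound 2, and its size is not readable, so it gives no direction. Compound 3 is therefore expected to show a number no higher from compound 2 to compound 3 (the limit leaves the size open) in this assay. The estimate for compound 3 is 100000 nM, ranging from 30000 nM to 300000 nM, with the result most probably again only a limit.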

Compound 3, half-maximal inhibitory concentration: > 100000 nM
Compound 3 was reported as a limit; the forecaster's own chance of this, stated with the estimate: 85%; the middle value lies on the limit itself.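

In this assay compound 3 gives > 100000 nM, which is a limit of the assay. No step among compound 1, compound 2 and compound 3 can be read, because all three results are limits: the limit of > 100000 nM in this assay, at which 3 of the 3 values shown sit.

The compounds shown leave open how far 4-chlorobenzyl, phenyl and pentyl on the amide-type nitrogen truly differ, and whether any group there gives a readable value.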